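The compounds below may be only part of what the source reports. "The series", "measured", "known", "first", "only" and "open" are said of these compounds alone.

Compound 1 `CCC(=O)Nc1ccc(-c2nc3cc(C(F)(F)F)ccc3n2C2CCCCC2)cc1` was examined in an ADME assay on Vero cells (Chlorocebus sabaeus) for cytotoxicity (on this read-out lower numbers stand for higher toxicity in this test and higher numbers for lower toxicity in this test), where it gives only a limit of the assay, > 100000 nM. Compound 2 `CCC(=O)Nc1ccc(-c2nc3cc(C(F)(F)F)ccc3[nH]2)cc1` likewise reaches only a limit, > 100000 nM, in this assay. Going by the values given here, compound 3 `CC(=O)Nc1ccc(-c2nc3cc(C(F)(F)F)ccc3n2C2CCCCC2)cc1` is the one member of the set with a number rather than a limit: in this assay compound 3 gives 30000 nM. The two cores of compound 1 and compound 3 differ by hydrogen in place of methyl on a saturated chain carbon bound to a carbonyl carbon, and that change produced an at least 3.3-fold lower number from compound 1 to compound 3 (0.52 log units; beyond the scatter). The change hydrogen in place of cyclohexyl on an aromatic nitrogen made a step that the two limits leave unreadable from compound 1 to compound 2, a step that cannot be sized because the limit of > 100000 nM in this assay, at which 2 of the 3 values shown sit, holds both ends of it. Compound 4 `CC(=O)Nc1ccc(-c2nc3cc(C(F)(F)F)ccc3[nH]2)cc1` carries the same change, (hydrogen in place of cyclohexyl on an aromatic nitrogen), now applied to compound 3. In this assay the step of a 1.5-fold higher number from compound 3 to compound 4 (0.18 log units; within the scatter) is expected, resting on a step that the two limits leave unreadable from compound 1 to compound 2, whose two ends sit at the same limit and so show no readable shift for this change. For compound 4 the estimated value in this assay is 45000 nM, with a range expected from 15000 nM to 100000 nM.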

Compound 4, half-maximal cytotoxic concentration: 50000 nM
The estimate for compound 4 lay 1.1-fold (0.05 log units) below the measured number; the range from low to high includes it.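

In this assay, hydrogen in place of cyclohexyl on the aromatic nitrogen gave a 1.7-fold higher number from compound 3 to compound 4 (0.22 log units; within the scatter), a step within the scatter, while the same change between compound 1 and compound 2 cannot be read, as both of its ends are limits. Hydrogen in place of methyl on the saturated chain carbon bound to the carbonyl carbon gave an at least 2.0-fold lower number from compound 2 to compound 4 (0.30 log units; that floor lies within the scatter), which can be set beside the step on the cyclohexyl core. The two steps point the same way, which shows that the direction of this change carried over between the two cores, but they give floors rather than sizes, so they do not show that its size carried over: the same change on two cores in this assay, an at least 3.3-fold lower number (0.52 log units; beyond the scatter) from compound 1 to compound 3 and an at least 2.0-fold lower number (0.30 log units; that floor lies within the scatter) from compound 2 to compound 4; the limit leaves it open whether they differ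

The compounds shown leave open how a longer chain on the carbonyl carbon would read in this assay. They also leave open what a phenyl ring on the aromatic nitrogen, or an amine or a carboxylic acid in place of the trifluoromethyl, would do to this read-out.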